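This account rests on a few compounds, and the source may have more. Where it says the series, first, only, none or still open, it means among the compounds named here.

Three analogues that share a sulfonamide-linked core were tested in a functional assay on IMR-32 cells (Homo sapiens) for cytotoxicity, read by MTT assay, tested at 60 ug/mL; a lower number here means less inhibition, a higher number more inhibition at the concentration tested (going by the name of the read-out). Compound 1, `CCNC(=O)CCC(NS(=O)(=O)c1cc(Cl)ccc1Cl)C(=O)NCC`, gives 12.9%. Compound 2, `CC(C)NC(=O)CCC(NS(=O)(=O)c1cc(Cl)ccc1Cl)C(=O)NC(C)C`, gives 16.7%. Compound 3, `O=C(CCC(NS(=O)(=O)c1ccc(Br)cc1)C(=O)NC1CCCCC1)NC1CCCCC1`, gives 18.4%. On these three numbers compound 2 sits in the middle: the number of compound 3 differs from it by an amount within the usual scatter, and the number of compound 1 also differs from it by an amount within the scatter, so the three compounds cannot be told apart on this assay.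

Compound 4, `Cc1ccc(Cl)c(S(=O)(=O)NC(CCC(=O)NC(C)C)C(=O)NC(C)C)c1`, has not yet been measured in this assay. It differs from compound 2 in one place: methyl in place of chloro on an aromatic carbon. The change keeps the heavy-atom count and the donor and acceptor counts unchanged, and only the 2,5-dichlorophenyl becomes 2-chloro-5-methylphenyl.

Going by the values given here, since the compounds measured so far all fall within the scatter of one another in this assay, compound 4 is expected to do the same, and the step from compound 2 to compound 4 is estimated at a number 1.7 percentage points lower from compound 2 to compound 4 (within the scatter), that is, no step beyond the scatter in either direction. Compound 4 is therefore expected to give about 15% in this assay, with a likely range from 5% to 27%.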

Compound 4, a percentage reported as inhibition, at one concentration (the size of the read-out at that concentration, not a potency): 29.8%
The estimate for compound 4 lay 14.8 percentage points below the measured number; the measured number lies above the stated range.
By their numbers in this assay, from the lowest: compounds 1, 2 and 3 (each within the scatter of the next); then compound 4.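

Replacing chloro with methyl on this aromatic carbon, meta to a large group and para to a chloro group, gives a number 13.1 percentage points higher from compound 2 to compound 4 (beyond the scatter) in this assay. This is the first comparison shown between compounds that differ in one place, and it shows that this ring position is not silent: exchanging one heavy atom for another, with the donor and acceptor counts unchanged, is enough to take the number beyond the scatter, so the 2-chloro-5-methylphenyl of compound 4 is set apart from the 2,5-dichlorophenyl of compound 2. Nothing measured here explains the step, so the pair records its size and direction but not its origin.

A single pair cannot tell whether the step comes from gaining the methyl or from losing the chloro, and a hydrogen, a methoxy group, a trifluoromethyl group or an ethyl group at the same carbon would help to separate the two readings. On these data alone, it also remains open whether the same exchange would give a similar step with the amide groups of compound 1 in place of those of compound 2.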